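This account rests on a few compounds, and the source may have more. Where it says the series, first, only, none or still open, it means among the compounds named here.

Of the compounds shown here, three built on a shared core have been tested in an assay on cells for inhibition of Amine oxidase [flavin-containing] B (Homo sapiens), read by Amplex Red, with stated times of 30 min and 45 min; a higher number here means a weaker inhibitor, a lower number a stronger inhibitor. Compound 1 `C#CCCOc1ccc2cc(C(=O)OC)c(=O)oc2c1` gives 258 nM in this assay. Compound 2 `C#CCCCOc1ccc2cc(C(=O)OC)c(=O)oc2c1` differs from compound 1 by one change, (propargyl in place of ethynyl on a saturated chain carbon, two bonds along the chain from an oxygen on an aromatic ring), and in this assay compound 2 gives 82.4 nM; this change brings a 3.1-fold lower number from compound 1 to compound 2 (0.50 log units; beyond the scatter). Compound 3 `C#CCCCOc1ccc2cc(NC(C)=O)c(=O)oc2c1` carries acetamido in place of methoxycarbonyl on an aromatic carbon relative to compound 2, and in this assay compound 3 gives 43.6 nM, a step of a 1.9-fold lower number from compound 2 to compound 3 (0.28 log units; within the scatter). How the core of compound 3 differs from the core of compound 1 is not broken down here; the two values simply show compound 3 with the lower number.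

Compound 4 `C#CCCCCOc1ccc2cc(NC(C)=O)c(=O)oc2c1` has not been measured. It differs from compound 3 by propargyl in place of ethynyl on a saturated chain carbon, three bonds along the chain from an oxygen on an aromatic ring. The groups that leave and enter are the same as in the change from compound 1 to compound 2, and the change occurs twice among these compounds in all, but the place is not identical: in one case the saturated chain carbon lies two bonds along the chain from the oxygen on the aromatic ring, in the other three bonds along. It is therefore the same kind of change, not the same change. Among the compounds with values here, the only guide is that earlier step, and because a 3.1-fold lower number from compound 1 to compound 2 (0.50 log units; beyond the scatter) rests on a single precedent that sits one bond closer to the oxygen, compound 4 is expected to give a smaller step, a 1.5-fold lower number from compound 3 to compound 4 (0.16 log units; within the scatter). Compound 4 is estimated at 30 nM in this assay, with an expected range from 10 nM to 100 nM.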

Compound 4, half-maximal inhibitory concentration: 41.7 nM
Compound 4: the middle estimate sits 1.4-fold (0.14 log units) below what was measured; measured number inside the range.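

In this assay, propargyl in place of ethynyl on a saturated chain carbon, three bonds along the chain from an oxygen on an aromatic ring, gives a 1.0-fold lower number from compound 3 to compound 4 (0.02 log units; within the scatter), leaving compound 3 and compound 4 not distinguishable in this measurement. Set beside the earlier step, the change does not carry over at the same size from one core to the other: the same change on two cores in this assay, a 3.1-fold lower number (0.50 log units; beyond the scatter) from compound 1 to compound 2 and a 1.0-fold lower number (0.02 log units; within the scatter) from compound 3 to compound 4, 3.0-fold (0.48 log units) apart, beyond the scatter of two such steps What this does not show is the source of that gap, since the two steps differ both in the group on the aromatic carbon, methoxycarbonyl in one pair and acetamido in the other, and in the place of the change, two bonds along the chain from the oxygen in one pair and three bonds along in the other, and with one pair on each side these two differences cannot be separated.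

The compounds shown leave open how a hex-5-yn-1-yl chain behaves with methoxycarbonyl on the aromatic carbon and how a but-3-yn-1-yl chain behaves with acetamido there, the two pairings that would pull chain and core apart. Also open, as far as these compounds go, is what a longer chain than hex-5-yn-1-yl, or an amine or a carboxylic acid in place of acetamido, would give in this assay.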